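A Nitrooxymethyl Ester in Place of an Aromatic Ester

The compounds below may be only part of what the source reports. "The series", "measured", "known", "first", "only" and "open" are said of these compounds alone.

Measured compounds:
Compound 1 `CC(=O)Oc1ccccc1C(=O)O[C@H]1CO[C@H]2[C@@H]1OC[C@H]2OC(=O)c1ccccc1C` gives 0.035 h in an ADME assay on a cell-free system (plasma, Homo sapiens) for metabolic stability, with Plasma (Rattus norvegicus) as the target, read by HPLC, at pH 7.4; a higher number here means that the compound lasts longer, a lower number that the compound disappears faster.
Compound 2 `CC(=O)Oc1ccccc1C(=O)O[C@H]1CO[C@H]2[C@@H]1OC[C@H]2OC(=O)c1cnccc1Cl` gives 0.0642 h in this assay.

Going by the values given here, compound 1 stands at the lower of the two numbers measured so far, and its only neighbour, compound 2, is close: the change a 1.8-fold higher number from compound 1 to compound 2 (0.26 log units; within the scatter), so the two compounds cannot be told apart on these data.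

The unmeasured compound 3 `CC(=O)Oc1ccccc1C(=O)O[C@H]1CO[C@H]2[C@@H]1OC[C@H]2OC(=O)CO[N+](=O)[O-]` differs from compound 1 in one place: (nitrooxy)methyl in place of 2-methylphenyl on a carbonyl carbon. Among the compounds with values here, the group that enters is not a ring at all, whereas the one step measured so far exchanged one six-membered aromatic ring for another and stayed within the scatter. Within the data shown here, no measured step therefore speaks directly to the size of this change, and the short half-life of compound 1 leaves little room for a much lower number before the read-out becomes a limit.

With only this to go on, compound 3 is expected to stay near compound 1, the step of a 1.2-fold lower number from compound 1 to compound 3 (0.07 log units; within the scatter) being the estimate, with a wide range. The estimated half-life of compound 3 in this assay is 0.03 h, between 0.01 h and 0.1 h.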

Compound 3, half-life: 0.06 h
Compound 3: middle estimate off by 2.0-fold (0.30 log units), on the low side, and the stated range covers the measured number.
By their numbers in this assay, from the lowest: compounds 1, 3 and 2 (each within the scatter of the next).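

In this assay, going by these compounds alone, (nitrooxy)methyl is the only one of the three groups on this carbonyl carbon that has no ring, yet the step from the 2-methylphenyl group stays within the scatter (a 1.7-fold higher number from compound 1 to compound 3 (0.23 log units; within the scatter)). The comparison with the 4-chloropyridin-3-yl group gives the same reading (a 1.1-fold lower number from compound 2 to compound 3 (0.03 log units; within the scatter)), so compound 1, compound 2 and compound 3 cannot be told apart on these numbers. The position therefore tolerates the loss of the six-membered aromatic ring, and the entry of a group with 5 heavy atoms and 3 hydrogen-bond acceptors, without a step beyond the scatter, which the exchange of one aromatic ring for another could not show.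

Nothing in the data at hand accounts for how closely these half-lives lie together. The compounds shown leave open whether a plain methyl without the nitrooxy part, a longer chain or an amine on this carbonyl carbon would give a number outside the scatter, and since all three keep the rest of the structure unchanged, they say nothing about changes made elsewhere on the core.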